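Adding Chloro to the Urea Aryl Ring of Compound 1

The source may hold more compounds than are shown below. What is called first, only, known or untested is meant among the compounds shown, and "the series" means these compounds.

Two compounds have been examined so far in a functional assay on HOP-62 cells (Homo sapiens) for inhibition, read by sulforhodamine B assay, with a stated time of 48 h; a lower number here means a stronger inhibitor of growth, a higher number a weaker inhibitor of growth. Compound 1, `O=C(Nc1cccc(-n2cc(-c3ccncc3)c(-c3ccc(Cl)c(O)c3)n2)c1)Nc1cccc(C(F)(F)F)c1`, gives 6860 nM, the highest of the two numbers. Compound 2, `COc1cc(-c2nn(-c3cccc(NC(=O)Nc4cccc(C(F)(F)F)c4)c3)cc2-c2ccncc2)ccc1Cl`, gives 1340 nM, and the step of a 5.1-fold lower number from compound 1 to compound 2 (0.71 log units; beyond the scatter) comes from a change on the oxygen of the phenol ring, not on the urea side of the molecule.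

Compound 3, `O=C(Nc1cccc(-n2cc(-c3ccncc3)c(-c3ccc(Cl)c(O)c3)n2)c1)Nc1ccc(Cl)c(C(F)(F)F)c1`, is to be measured next. It differs from compound 1 by chloro in place of hydrogen on an aromatic carbon. Among the compounds with values here, no measured step touches this part of the molecule, so the only step known, a 5.1-fold lower number from compound 1 to compound 2 (0.71 log units; beyond the scatter), offers no direct guide; it shows merely that a small change elsewhere can move the number beyond the scatter. The estimate for compound 3 in this assay is therefore cautious: a step of a 2.0-fold lower number from compound 1 to compound 3 (0.29 log units; within the scatter) is expected, giving compound 3 an expected value of 3500 nM, with a range from 1000 nM to 12000 nM.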

Compound 3, concentration for 50% growth inhibition: 1220 nM
Compound 3: the middle estimate sits 2.9-fold (0.46 log units) above what was measured; measured number inside the range.
By their numbers in this assay, from the lowest: compounds 3 and 2 (each within the scatter of the next); then compound 1.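

In this assay, chloro in place of hydrogen on the 3-(trifluoromethyl)phenyl ring gives a 5.6-fold lower number from compound 1 to compound 3 (0.75 log units; beyond the scatter) and so shows that the urea side of the molecule, untouched by the earlier step, can also move the number beyond the scatter. The change adds a single heavy atom, ortho to a trifluoromethyl group and para to a large group, while the hydroxyl group of compound 1 stays in place. No accompanying measurement bears on why the number falls.

On these data alone, whether bromo, methyl, methoxy or an amine at this same position would give a similar step remains open. Also open, as far as these compounds go, is whether this chloro and the methyl on the oxygen, which gave a 5.1-fold lower number from compound 1 to compound 2 (0.71 log units; beyond the scatter), would add up when placed together in one compound.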